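Moving a Methyl Group on a Chemokine Receptor Ligand

The source may report more compounds than this note shows. Statements on the series, on what has been measured and on what is new or still open speak of the compounds shown alone.

Three measured compounds share one core and differ in the group attached to the carbonyl carbon and in one further substituent. In an assay on THP-1 cells for displacement of a labelled ligand from C-C chemokine receptor type 1 (Homo sapiens) (a higher number here means a weaker inhibitor, a lower number a stronger inhibitor), compound 1 `CC[C@@H](NC(=O)c1ccccc1)C(=O)N1CCC(c2ccc(Cl)cc2)CC1` gives 121 nM and compound 3 `CC(C)C(NC(=O)c1ccccc1)C(=O)N1CCC(c2ccc(F)cc2)CC1` gives 423 nM, while compound 2 `Cc1ccc(C(=O)N[C@@H](C(=O)N2CCC(c3ccc(Cl)cc3)CC2)C(C)C)cc1` gives 25 nM, the lowest of the three numbers and beyond the scatter from both others, so compound 2 is the strongest inhibitor of the set. Compound 4 `Cc1ccccc1C(=O)N[C@@H](C(=O)N1CCC(c2ccc(Cl)cc2)CC1)C(C)C` differs from compound 2 in a single place: 2-methylphenyl in place of 4-methylphenyl on a carbonyl carbon. Going by the values given here, no measured pair shows the outcome of such a change, so the size and direction of the step are open; a modest weakening is expected, a step of a 2.4-fold higher number from compound 2 to compound 4 (0.38 log units; beyond the scatter). Compound 4 is therefore estimated at 60 nM, within a range from 15 nM to 250 nM.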

Compound 4, half-maximal inhibitory concentration: 32 nM
Compound 4: the middle estimate sits 1.9-fold (0.27 log units) above what was measured; low and high end bracket the measured number.
By their numbers in this assay, from the lowest: compounds 2 and 4 (each within the scatter of the next); then compound 1; then compound 3.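

In this assay, 2-methylphenyl in place of 4-methylphenyl on a carbonyl carbon gives a 1.3-fold higher number from compound 2 to compound 4 (0.11 log units; within the scatter), so the two compounds cannot be told apart. Going by these compounds alone, this is the first direct view of this position: with the same atoms joined differently, the place of the methyl group on this ring leaves no readable mark on the number. Nothing measured here offers an explanation for this result. As far as these compounds go, what a carboxylic acid or an amine in place of that methyl group would do remains open.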